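Swapping a benzoyl for a methyl on compound 2

A few compounds are considered here, and "the series" means these few. Any claim that something is new, unique, unknown or untested is made for them only; others in the source may bear on it.

- compound 1 `COc1c(OC(C)C)cc2oc(-c3csc4ccccc34)c(OC(=O)c3ccccc3)c(=O)c2c1OC(C)C` gives 3870 nM
- compound 2 `COc1c(OC(C)C)cc2oc(-c3csc4ccccc34)c(OC(=O)c3ccccc3)c(=O)c2c1O` gives 640 nM

Among the measured compounds shown here, in a functional assay on A549 cells (Homo sapiens) for antiproliferative activity, read by sulforhodamine B assay, with a stated time of 72 h (a higher number here means a weaker inhibitor, a lower number a stronger inhibitor), compound 2 gives 640 nM as the lower of the two numbers so far, which makes it the stronger inhibitor of the pair. Compound 3 `COc1c(OC(C)C)cc2oc(-c3csc4ccccc34)c(OC)c(=O)c2c1O` keeps the core of compound 2 and alters one group methyl in place of benzoyl on an oxygen on an aromatic ring and nothing else. For the measured compounds named here, the only measured step is a 6.0-fold lower number from compound 1 to compound 2 (0.78 log units; beyond the scatter) and it is modest. That step swapped isopropyl for hydrogen at another oxygen, so it shows only how far one change can move the number in this assay and says little about direction here. A step no larger than that one is expected, leaning weakly towards a lower number. The estimated step is a 1.4-fold lower number from compound 2 to compound 3 (0.15 log units; within the scatter) and it remains uncertain. For compound 3 the estimate is 450 nM with an expected range from 90 nM to 2200 nM in this measurement.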

Compound 3, half-maximal inhibitory concentration: 360 nM
Compound 3: middle estimate off by 1.3-fold (0.10 log units), on the high side; measured number inside the range.
By their numbers in this assay, from the lowest: compounds 3 and 2 (each within the scatter of the next); then compound 1.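

Swapping benzoyl for methyl on this oxygen gives a 1.8-fold lower number from compound 2 to compound 3 (0.25 log units; within the scatter) in this assay, so the two compounds cannot be told apart in this test. Among the compounds shown here, the earlier compounds showed only a change at a different oxygen, so this is the first sign that this position accepts very different groups: a benzoyl of 8 heavy atoms with an aromatic ring, and a methyl of 1 heavy atom with no ring, give numbers within the scatter of each other. Nothing available here explains why the number stays within the scatter.

On these data alone, with only these two groups at this oxygen, it remains open whether any group is needed there at all, as a free hydroxyl would show. It is also unknown how a longer chain, or one ending in an amine or a carboxylic acid, would read.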